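The compounds below may be only part of what the source reports. "The series", "measured", "known", "first", "only" and "open" are said of these compounds alone.

Compound 1 `CN(CCNCc1cn(-c2ccc(Cl)cc2)nn1)CCNc1ccnc2cc(Cl)ccc12` and compound 2 `CN(CCNCc1cn(-c2cccc(Cl)c2)nn1)CCNc1ccnc2cc(Cl)ccc12` share one core and differ only in the group on the aromatic nitrogen. Among the measured compounds shown here, in a functional assay on BXPC-3 cells (Homo sapiens) for antiproliferative activity, read by sulforhodamine B assay, with a stated time of 72 h (a lower number here means a stronger inhibitor, a higher number a weaker inhibitor), compound 1 gives 9100 nM, and compound 2 gives 12000 nM; the step of a 1.3-fold higher number from compound 1 to compound 2 (0.12 log units; within the scatter) leaves the two values within the scatter of each other, so compound 1 stands level with its only neighbour. Compound 3 `CN(CCNCc1cn(-c2ccnc3cc(Cl)ccc23)nn1)CCNc1ccnc2cc(Cl)ccc12` carries the change (7-chloroquinolin-4-yl in place of 4-chlorophenyl on an aromatic nitrogen). For the measured compounds named here, the one measured step at this position, that from compound 1 to compound 2, lay within the scatter, so no direction is fixed for this larger change. Compound 3 is therefore expected to give 6000 nM, within 2000 nM to 20000 nM, an estimated step of a 1.5-fold lower number from compound 1 to compound 3 (0.18 log units; within the scatter).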

Compound 3, half-maximal inhibitory concentration: 8800 nM
Estimate against measurement, compound 3: 1.5-fold (0.17 log units) below; measured number inside the range.
By their numbers in this assay, from the lowest: compounds 3, 1 and 2 (each within the scatter of the next).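

With a 1.0-fold lower number from compound 1 to compound 3 (0.01 log units; within the scatter) and a 1.4-fold lower number from compound 2 to compound 3 (0.13 log units; within the scatter) in this assay, the larger 7-chloroquinolin-4-yl group on the aromatic nitrogen stands level with both chlorophenyl groups. The position thus accepts a second six-membered aromatic ring, with its ring nitrogen, without the number leaving the scatter. No evidence on why this is so is at hand. All three groups shown are chlorinated aromatic rings, so it remains open whether an amine, a carboxylic acid or a longer alkyl chain at this position would move the number beyond the scatter.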